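Fluoro to trifluoromethyl on a thiosemicarbazone aryl ring

The compounds below may be only part of what the source reports. "The series", "measured", "known", "first", "only" and "open" are said of these compounds alone.

Measured compounds:
compound 1, `FC(F)(F)c1ccccc1NC(=S)N/N=C/c1ccc2ccccc2n1`, 20700 nM
compound 2, `Fc1ccccc1NC(=S)N/N=C/c1ccc2ccccc2n1`, > 100000 nM
compound 3, `Fc1ccc(NC(=S)N/N=C/c2ccc3ccccc3n2)cc1`, 32300 nM

The three measured compounds share one core and differ only in the aryl group on the amide-type nitrogen. In a functional assay on SGC-7901 cells (Homo sapiens) for antiproliferative activity, read by sulforhodamine B assay, with a stated time of 72 h (a higher number here means a weaker inhibitor, a lower number a stronger inhibitor), compound 1 gives 20700 nM. In this assay compound 3 gives 32300 nM; these two values lie within the scatter of each other. For compound 2 the assay reports only a limit, > 100000 nM, and not a number.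

Two changes connect the measured compounds. The first is trifluoromethyl in place of fluoro on an aromatic carbon, and it gives an at least 4.8-fold lower number from compound 2 to compound 1 (0.68 log units; beyond the scatter); the step can only be stated as a lower bound because of the limit of > 100000 nM in this assay, at which 1 of the 3 values shown sits. The second is 4-fluorophenyl in place of 2-fluorophenyl on an amide-type nitrogen, with an at least 3.0-fold lower number from compound 2 to compound 3 (0.49 log units; beyond the scatter), again bounded by that limit.

Compound 4, `FC(F)(F)c1ccc(NC(=S)N/N=C/c2ccc3ccccc3n2)cc1`, has not yet been measured. It differs from compound 3 by trifluoromethyl in place of fluoro on an aromatic carbon. This is the same kind of change as from compound 2 to compound 1, but the place is not the same: in compound 1 the trifluoromethyl sits ortho to a large group, in compound 4 para to a large group. Among the measured compounds shown here, since the only measured example of this change, an at least 4.8-fold lower number from compound 2 to compound 1 (0.68 log units; beyond the scatter), starts from a limit, its true size is unknown, so a smaller step is expected here, a 2.7-fold lower number from compound 3 to compound 4 (0.43 log units; beyond the scatter). Compound 4 is therefore expected to give about 12000 nM in this assay, with a likely range from 3500 nM to 40000 nM.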

Compound 4, half-maximal inhibitory concentration: 72200 nM
Estimate against measurement, compound 4: 6.0-fold (0.78 log units) below; the whole stated range lies below it.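

In this assay, putting trifluoromethyl in place of fluoro, on an aromatic carbon and para to a large group, gives a 2.2-fold higher number from compound 3 to compound 4 (0.35 log units; beyond the scatter), so here the swap makes the compound a weaker inhibitor rather than a stronger one. Set beside the earlier example, the same swap moves the number in opposite directions, and the two steps differ by more than repeat measurements would explain, so the effect of this change does not carry over unaltered from one core to the other: the same change on two cores in this assay, an at least 4.8-fold lower number (0.68 log units; beyond the scatter) from compound 2 to compound 1 and a 2.2-fold higher number (0.35 log units; beyond the scatter) from compound 3 to compound 4, at least 10-fold (1.03 log units) apart, beyond the scatter of two such steps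

This does not show why the direction differs, or which way the swap would go on a further core, and compound 2 has only a limit, so the earlier step has a bound and not an exact size: the limit of > 100000 nM in this assay, at which 1 of the 4 values shown sits.

The compounds shown leave open how other groups in the same place on the ring, such as a chloro, a methoxy, an amine or a carboxylic acid, would read in this assay. They also leave open whether the opposite steps seen here would hold up in a larger set of matched pairs, where each pair differs only by this one swap.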